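The compounds below may be only part of what the source reports. "The series", "measured", "known", "first", "only" and "open" are said of these compounds alone.

In a functional assay on HepG2 cells (Homo sapiens) for inhibition, read by MTT assay, with a stated time of 72 h (a higher number here means a weaker inhibitor, a lower number a stronger inhibitor), compound 1 (`Nc1nc2cc(-c3nn(CCC(=O)NO)c4ncnc(N)c34)ccc2o1`) reads > 150000 nM as a limit of the assay, not as a number. Compound 2 (`Nc1ncnc2c1c(-c1cnc3[nH]ccc3c1)nn2CCC(=O)NO`) reads > 150000 nM as a limit too. Compound 3 (`Nc1ncnc2c1c(-c1cnc3[nH]ccc3c1)nn2CCCC(=O)NO`) reads > 50000 nM as a limit as well. So compound 1 has no measured potency to start from, and neither do its two neighbours.

Compound 4 (`CNC(=O)CCCCCCCn1nc(-c2ccc3oc(N)nc3c2)c2c(N)ncnc21`) differs from compound 1 in one place (5-(methylcarbamoyl)pentyl in place of hydroxycarbamoyl on a saturated chain carbon, two bonds along the chain from an aromatic nitrogen). The hydroxycarbamoyl group leaves, and 5-(methylcarbamoyl)pentyl enters on a saturated chain carbon, two bonds along the chain from an aromatic nitrogen.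

Going by the values given here, only one measured step touches this chain (a step that the two limits leave unreadable from compound 2 to compound 3), and it gives neither a size nor a direction. The expected step (an at least 3.0-fold lower number from compound 1 to compound 4 (0.47 log units; beyond the scatter)) is therefore a rough estimate, and the assay may well report only a limit again. For compound 4 the estimated value is 50000 nM (expected range 10000 nM to 150000 nM) in this assay when a number is obtained.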

Compound 4, half-maximal inhibitory concentration: 3640 nM
Beside the measured number, compound 4's estimate is 14-fold (1.14 log units) above it, and the stated range ends above it.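

In this assay, putting 5-(methylcarbamoyl)pentyl in place of hydroxycarbamoyl gives an at least 41-fold lower number from compound 1 to compound 4 (1.61 log units; beyond the scatter). Going by these compounds alone, this shows that the group on this saturated chain carbon, two bonds along the chain from an aromatic nitrogen, can bring the read-out from a limit to a real number, whereas the only earlier step at this place cannot be read. The size of the new step is only a lower bound, because compound 1 stands at a limit and not at a number: the limit of > 150000 nM in this assay, at which 2 of the 4 values shown sit.

The new group differs from the old one in both chain length and end group, so the compounds shown cannot tell which of the two accounts for the change. A carboxylic acid at the end of the same long chain, or a methylcarbamoyl on the short chain, would help to separate the two.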